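Shifting the aryl substituent pattern on the ring nitrogen

This account rests on a few compounds, and the source may have more. Where it says the series, first, only, none or still open, it means among the compounds named here.

Of the compounds shown here, three sharing one core have been measured in an assay on isolated protein for inhibition of protein kinase C zeta type (Homo sapiens), with a stated time of 4 min, tested at 62.5 uM; on this read-out higher numbers stand for more inhibition at the one concentration tested (going by the name of the read-out) and lower numbers for less inhibition. Compound 1 `CC(C)(C)C1=NN(c2ccc(C(F)(F)F)cc2)C(c2ccc(O)cc2)C1` gives 94.2%, and compound 2 `Cc1cccc(N2N=C(C(C)(C)C)CC2c2ccc(O)cc2)c1` gives 91.7%. Compound 3 `CC(C)(C)C1=NN(c2ccccc2Cl)C(c2ccc(O)cc2)C1` gives 57.1%, the lowest of the three numbers; its nearest neighbour is compound 2, and its furthest is compound 1, both beyond the scatter.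

Within the data shown here, the one measured step that reaches compound 3 is a number 34.6 percentage points lower from compound 2 to compound 3 (beyond the scatter), a large fall. Compound 4 `Cc1ccc(N2N=C(C(C)(C)C)CC2c2ccc(O)cc2)c(C)c1` has not yet been measured in this assay; it differs from compound 3 by 2,4-dimethylphenyl in place of 2-chlorophenyl on an amine nitrogen in a ring. Among the measured compounds shown here, no measured step shows a 2,4-dimethylphenyl group, so the expectation rests on the fall from compound 2 to compound 3 and on the high numbers of compound 1 and compound 2, both of which carry groups that are not 2-chlorophenyl. The step from compound 3 to compound 4 is therefore expected to be upward, a number 14.9 percentage points higher from compound 3 to compound 4 (beyond the scatter), though a group that still carries a substituent in the 2-position may not recover the full amount. Compound 4 is thus estimated at 72%, within a range from 48% to 92%.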

Compound 4, a percentage reported as inhibition, at one concentration (the size of the read-out at that concentration, not a potency): 59.9%
For compound 4 the middle estimate is 12.1 percentage points above the measured one; low and high end bracket the measured number.
By their numbers in this assay, from the lowest: compounds 3 and 4 (each within the scatter of the next); then compounds 2 and 1 (each within the scatter of the next).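

Replacing 2-chlorophenyl with 2,4-dimethylphenyl on the amine nitrogen in the ring gives a number 2.8 percentage points higher from compound 3 to compound 4 (within the scatter), so the two groups cannot be told apart at this position. Against 3-methylphenyl, the same 2,4-dimethylphenyl group gives a number 31.8 percentage points lower from compound 2 to compound 4 (beyond the scatter), a second large fall, which shows that the lower level is not tied to the chlorine atom: an aryl group of carbon only reaches it too. Nothing on hand explains why these two groups sit so far from the groups of compound 1 and compound 2.

The compounds shown do not separate the two methyl groups of 2,4-dimethylphenyl, so which of them goes with the lower number stays open. They also leave open how a phenyl group carrying an amine or a carboxylic acid would read at this position.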